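The compounds below may be only part of what the source reports. "The series", "measured", "known", "first", "only" and "open" are said of these compounds alone.

Compound 1 `COc1ccc(/C=C/C(=O)Nc2nc3ccc(Cl)cc3s2)cc1O` is an amide joined through a double bond to a ring that carries a methoxy and a hydroxy group. In a functional assay on the whole organism (Hindlimb, strain albino) with Mus musculus as the target, in the maximal electroshock model, with a stated time of 0.5 h (on this read-out lower numbers stand for an effect already at smaller amounts and higher numbers for an effect only at larger amounts of compound), compound 1 gives 320 umol/kg. Compound 2 `COc1ccc(/C=C/C(=O)Nc2nc3ccc(Cl)cc3s2)cc1` lacks the hydroxy group and gives 259 umol/kg. Compound 1 thus stands at the top of the two numbers measured, but the step of a 1.2-fold lower number from compound 1 to compound 2 (0.09 log units; within the scatter) lies within the scatter, so the two compounds cannot be told apart on this read-out.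

Compound 3 `COc1ccc(/C=C/C(=O)Nc2nc3ccc([N+](=O)[O-])cc3s2)cc1O` differs from compound 1 at a different place: nitro in place of chloro on an aromatic carbon. Going by the values given here, no measured step touches this position, so the single step known, from hydroxy to hydrogen, gives no guide, and the expectation rests on the change itself. With nothing pointing either way, no step beyond the scatter is expected, so compound 3 is estimated at 320 umol/kg, between 130 umol/kg and 800 umol/kg, a step of no change at the digits printed from compound 1 to compound 3 (within the scatter) that is expected to stay within the usual scatter.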

Compound 3, dose for half-maximal effect: 372 umol/kg
For compound 3 the middle estimate is 1.2-fold (0.07 log units) below the measured one; low and high end bracket the measured number.
By their numbers in this assay, from the lowest: compounds 2, 1 and 3 (each within the scatter of the next).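

Exchanging chloro for nitro gives a 1.2-fold higher number from compound 1 to compound 3 (0.07 log units; within the scatter) in this assay. This position, which the step from hydroxy to hydrogen did not touch, therefore accepts a group with more heavy atoms and with hydrogen-bond acceptors where chloro has none, and the read-out stays within the scatter, so compound 1 and compound 3 cannot be told apart. Nothing available here bears on why this exchange leaves the number within the scatter.

An amine, a carboxylic acid or a plain hydrogen at this same aromatic carbon could still show whether any group here can move the number beyond the scatter. Also open, as far as these compounds go, is how the core behaves when nitro and the loss of hydroxy are combined in one compound.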